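The source may hold more compounds than are shown below. What is called first, only, known or untested is meant among the compounds shown, and "the series" means these compounds.

Values in a functional assay on CCRF-CEM cells (Homo sapiens) for cytotoxicity; on this read-out lower numbers stand for higher toxicity in this test and higher numbers for lower toxicity in this test:
- compound 1 `O=C1c2ccccc2NS(=O)(=O)N1COCCO`: > 200 ug/mL (a limit)
- compound 2 `O=C1c2ccccc2N(COCc2ccccc2)S(=O)(=O)N1Cc1ccccc1`: 25 ug/mL
- compound 3 `CC(=O)OCCOCN1c2ccccc2C(=O)NS1(=O)=O`: > 200 ug/mL (a limit)

Among the compounds with values here, compound 2 holds the only true number of the three, 25 ug/mL. Compound 1 and compound 3 give no number, only (the limit of > 200 ug/mL in this assay, at which 2 of the 3 values shown sit).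

The next compound to be tested is compound 4 `O=C1c2ccccc2N(COCCO)S(=O)(=O)N1Cc1ccccc1`. It differs from compound 2 in one place: hydroxymethyl in place of phenyl on a saturated chain carbon bound to an oxygen on a saturated carbon. Hydroxymethyl stands in place of phenyl on a saturated chain carbon bound to an oxygen on a saturated carbon, so that, read one bond further out, benzyloxy becomes 2-hydroxyethoxy.

Within the data shown here, no measured pair shows this change alone, so any step here is an expectation. Compound 1 also carries the (2-hydroxyethoxy)methyl group, and it shows only the limit > 200 ug/mL. Among the measured compounds shown here, with that as the one guide, a moderate shift toward lower toxicity, beyond the scatter, is expected: a 3.2-fold higher number from compound 2 to compound 4 (0.51 log units; beyond the scatter). The estimated value for compound 4 is 80 ug/mL, with an expected range from 30 ug/mL to 200 ug/mL.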

Compound 4, half-maximal cytotoxic concentration: 89 ug/mL
For compound 4 the middle estimate is 1.1-fold (0.05 log units) below the measured one, and the stated range covers the measured number.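

In this assay, replacing the phenyl with hydroxymethyl on the chain gives a 3.6-fold higher number from compound 2 to compound 4 (0.55 log units; beyond the scatter), so this position responds to the change with a shift toward lower toxicity that can be put in numbers. Compound 4 still gives a true number rather than a limit, so carrying the (2-hydroxyethoxy)methyl group does not by itself put a compound out of measurable range. The earlier compounds could not show this, since the one number among them had no partner differing in one place and the other readings are limits: the limit of > 200 ug/mL in this assay, at which 2 of the 4 values shown sit.

On these data alone, it remains open whether the shift comes from losing the phenyl or from gaining the hydroxymethyl, which a plain propoxy group in the same place would help to separate. As far as these compounds go, how an amine or a carboxylic acid would read in place of the hydroxymethyl also stays open.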